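The source may hold more compounds than are shown below. What is called first, only, known or untested is meant among the compounds shown, and "the series" means these compounds.

Measured compounds:

Compound 1, `COc1cc(-c2cc(/C=C/C(=O)c3ccc(Cl)c(Cl)c3)[nH]n2)cc(OC)c1OC`, gives 96% in a functional assay on SN12C cells (Homo sapiens) for cytotoxicity, read by sulforhodamine B assay, with a stated time of 48 h, tested at 0.1 uM; a lower number here means a stronger effect, a higher number a weaker effect of the compound at the concentration tested.
Compound 2, `COc1ccc(-c2cc(/C=C/C(=O)c3cc(OC)c(OC)c(OC)c3)[nH]n2)cc1OC`, gives 99%.
Compound 3, `COc1ccc(C(=O)/C=C/c2cc(-c3cc(OC)c(OC)c(OC)c3)n[nH]2)cc1OC`, gives 94%.

Compound 3 stands alongside compound 1 and compound 2: the three numbers differ from one another by less than the usual scatter of this assay, so none of them can be set apart from the others.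

Compound 4, `COc1cc(C(=O)/C=C/c2cc(-c3cc(OC)c(OC)c(OC)c3)n[nH]2)cc(OC)c1OC`, differs from compound 3 in one place: methoxy in place of hydrogen on an aromatic carbon. For the measured compounds named here, the only measured step, a number 2 percentage points lower from compound 1 to compound 3 (within the scatter), changes a different part of the molecule, the group on the carbonyl carbon, and it stays within the scatter. Every change seen so far in this series has therefore left this assay essentially unchanged, and nothing in the data points to the added methoxy group behaving otherwise.

For compound 4 the expected outcome is a number 2 percentage points higher from compound 3 to compound 4 (within the scatter), a step that stays within the scatter. The estimate for compound 4 is 96%, within a range from 87% to 102%.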

Compound 4, a percentage reported as activity, at one concentration (the size of the read-out at that concentration, not a potency): 98%
Estimate against measurement, compound 4: 2 percentage points below; low and high end bracket the measured number.
By their numbers in this assay, from the lowest: compounds 3, 1, 4 and 2 (each within the scatter of the next).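

In this assay, methoxy in place of hydrogen on an aromatic carbon, ortho to a methoxy group, gives a number 4 percentage points higher from compound 3 to compound 4 (within the scatter), so this position accepts a further methoxy group without a readable change at the concentration tested. The same kind of replacement on the other six-membered aromatic ring gives a number 1 percentage points lower from compound 2 to compound 4 (within the scatter), so the change has now been seen in two places and stays within the scatter in both. Nothing measured here offers a reason for this result.

From the compounds shown here alone, whether an amine, a carboxylic acid or a longer chain such as ethoxy at this position would shift the number beyond the scatter remains open. Going by these compounds, it also remains open whether these steps would stay this small at another concentration in this assay.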